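This account rests on a few compounds, and the source may have more. Where it says the series, first, only, none or still open, it means among the compounds named here.

Compound 1 `Cc1cccc(C(=O)Nc2cnc3ccccc3c2)c1Br`: 660 nM
Compound 2 `O=C(Nc1cnc2ccccc2c1)c1cccc(Cl)c1O`: 340 nM
Compound 3 `Cc1cc(Br)cc(C(=O)Nc2cnc3ccccc3c2)c1O`: 470 nM

All three compounds were tested in a functional assay on HUVEC cells (Homo sapiens) for inhibition, read by ELISA and BrdU incorporation; on this read-out higher numbers stand for weaker inhibition and lower numbers for stronger inhibition. The value of compound 3 lies within the usual scatter of both compound 1 and compound 2, so it cannot be ranked against either. Compound 4 `Cc1cccc(C(=O)Nc2cnc3ccccc3c2)c1O` has hydrogen in place of bromo on an aromatic carbon, para to a hydroxy group (hydrogen in place of bromo on an aromatic carbon). Going by the values given here, no two measured compounds differ in only one place, so no measurement isolates this change. The expectation rests on how close the values stay despite differing groups, with compound 2 at 340 nM and compound 1 at 660 nM in the same test. In this assay the expected size is a 1.1-fold higher number from compound 3 to compound 4 (0.03 log units; within the scatter) and so no step beyond the scatter. For compound 4 the estimated value is 500 nM with an expected range from 200 nM to 1200 nM.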

Compound 4, half-maximal inhibitory concentration: 780 nM
For compound 4 the middle estimate is 1.6-fold (0.19 log units) below the measured one, and the stated range covers the measured number.
By their numbers in this assay, from the lowest: compounds 2, 3, 1 and 4 (each within the scatter of the next, the first and the last beyond it).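

In this assay, hydrogen in place of bromo on the aromatic carbon para to a hydroxy group gives a 1.7-fold higher number from compound 3 to compound 4 (0.22 log units; within the scatter) and so shows that bromo and hydrogen at this carbon cannot be told apart here. Methyl in place of chloro gives a 2.3-fold higher number from compound 2 to compound 4 (0.36 log units; beyond the scatter) and is the only one of the new steps beyond the scatter. Hydroxy in place of bromo gives a 1.2-fold higher number from compound 1 to compound 4 (0.07 log units; within the scatter) and likewise separates the two groups by no more than the scatter.

Going by these compounds, whether an amine or a carboxylic acid on the carbon that held the bromo would give a number beyond the scatter stays open. Nothing at hand explains any of these steps.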